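Aryl swap on the cinnamamide of compound 1

A few compounds are considered here, and "the series" means these few. Any claim that something is new, unique, unknown or untested is made for them only; others in the source may bear on it.

Compound 1 `Cc1ccc(/C=C/C(=O)Nc2ccc3nc(N4CCC(O)(C5CC5)CC4)nc(C)c3c2)cc1` sits second highest of the three numbers in a functional assay on CHO-K1 cells for antagonist activity at melanin-concentrating hormone receptor 1 (Homo sapiens), read by inositol phosphate accumulation, with stated times of 10 min and 45 min (on this read-out higher numbers stand for weaker inhibition and lower numbers for stronger inhibition), where compound 1 gives 107 nM. Compound 2 `Cc1nc(NCCNS(C)(=O)=O)nc2ccc(NC(=O)/C=C/c3ccc(OC(F)(F)F)cc3)cc12` gives 142 nM, within the scatter of compound 1, while compound 3 `Cc1nc(NCCCNS(C)(=O)=O)nc2ccc(NC(=O)/C=C/c3ccc(OC(F)(F)F)cc3)cc12` gives 32 nM. Going by the values given here, the one measured step, a 4.4-fold lower number from compound 2 to compound 3 (0.65 log units; beyond the scatter), lengthens the chain on the shared core and does not touch the aryl end. Compound 4 `Cc1nc(N2CCC(O)(C3CC3)CC2)nc2ccc(NC(=O)/C=C/c3ccc(Cl)cc3Cl)cc12` differs from compound 1 by 2,4-dichlorophenyl in place of 4-methylphenyl on a double-bonded chain carbon bound to a double-bonded chain carbon. Among the compounds with values here, no measured pair probes this aryl change, so no step beyond the scatter is expected in this assay, with wide uncertainty. Compound 4 is therefore estimated at 80 nM, range 25 nM to 250 nM, which means an expected step of a 1.3-fold lower number from compound 1 to compound 4 (0.13 log units; within the scatter).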

Compound 4, half-maximal inhibitory concentration: 575 nM
Estimate against measurement, compound 4: 7.2-fold (0.86 log units) below; measured number outside the range, above it.
By their numbers in this assay, from the lowest: compound 3; then compounds 1 and 2 (each within the scatter of the next); then compound 4.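

The aryl end of the cinnamamide is not a silent position: in this assay, 2,4-dichlorophenyl in place of 4-methylphenyl gives a 5.4-fold higher number from compound 1 to compound 4 (0.73 log units; beyond the scatter). Going by these compounds alone, this is the only measured step at this place, and it runs toward weaker inhibition, whereas the earlier step changed only the chain on the shared core. Nothing available accounts for the size or direction of this step.

Left open is how an unsubstituted phenyl or a phenyl carrying a single chlorine would read on the core of compound 1. Also open, going by these compounds, is whether the same aryl change reads the same way with the chains of compound 2 and compound 3.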